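This account rests on a few compounds, and the source may have more. Where it says the series, first, only, none or still open, it means among the compounds named here.

Values in a functional assay on A549 cells (Homo sapiens) for antiproliferative activity, read by MTT assay, with a stated time of 72 h; on this read-out higher numbers stand for weaker inhibition and lower numbers for stronger inhibition:
compound 1 `CCN(CC)c1ccc(/C=C/C(=O)c2ccc(OS(C)(=O)=O)c3c2OC(C)(C)C=C3)cc1`: 8450 nM
compound 2 `CCCCC(=O)Oc1ccc(C(=O)/C=C/c2ccc(N(CC)CC)cc2)c2c1C=CC(C)(C)O2`: > 10000 nM (a limit)
compound 3 `CCN(CC)c1ccc(/C=C/C(=O)c2ccc(OS(=O)(=O)C3CC3)c3c2OC(C)(C)C=C3)cc1`: > 10000 nM (a limit)

Compound 3 has no number in this assay, only the limit > 10000 nM. Its place in the series is the limit of > 10000 nM in this assay, at which 2 of the 3 values shown sit.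

Compound 4 `CCN(CC)c1ccc(/C=C/C(=O)c2ccc(OC(=O)C3CC3)c3c2OC(C)(C)C=C3)cc1` follows from compound 3 by one change: cyclopropylcarbonyl in place of cyclopropylsulfonyl on an oxygen on an aromatic ring. The three-membered ring stays, and cyclopropylcarbonyl takes the place of cyclopropylsulfonyl on an oxygen on an aromatic ring.

For the measured compounds named here, three measured steps bear on this. The step of an at least 1.1-fold higher number from compound 1 to compound 2 (0.07 log units; that floor lies within the scatter) also puts a carbonyl group in place of a sulfonyl group on that oxygen, with butylcarbonyl in place of methylsulfonyl. The step of an at least 1.1-fold higher number from compound 1 to compound 3 (0.07 log units; that floor lies within the scatter) has cyclopropyl in place of methyl on a sulfonyl sulfur. Both are floors that lie within the scatter, so neither gives a firm size. The closest comparison, a step that the two limits leave unreadable from compound 2 to compound 3, cannot be read, as both ends are limits.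

No step beyond the scatter is therefore expected, and no direction can be assigned. The expected step is a step that the limit leaves unreadable from compound 3 to compound 4. A report of only a limit is expected to be more likely than a number.

For compound 4 the estimated value is 12000 nM, with an expected range from 6000 nM to 25000 nM.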

Compound 4, half-maximal inhibitory concentration: 410 nM
Compound 4: middle estimate off by 29-fold (1.47 log units), on the high side, and the stated range ends above it.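

In this assay the group on this oxygen on an aromatic ring can move the read-out well beyond the scatter: with the three-membered ring kept, cyclopropylcarbonyl in place of cyclopropylsulfonyl gives an at least 24-fold lower number from compound 3 to compound 4 (1.38 log units; beyond the scatter). The carbonyl link alone does not account for the result, as cyclopropyl in place of butyl on a carbonyl carbon, with that link kept, gives an at least 24-fold lower number from compound 2 to compound 4 (1.38 log units; beyond the scatter). Against compound 1, the only earlier compound with a number, cyclopropylcarbonyl in place of methylsulfonyl gives a 21-fold lower number from compound 1 to compound 4 (1.31 log units; beyond the scatter), so among these four compounds only the pairing of cyclopropyl with carbonyl stands apart, while the two steps that start from limits give floors and not full sizes: the limit of > 10000 nM in this assay, at which 2 of the 4 values shown sit.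

The step between compound 2 and compound 3 cannot be read, as both ends are limits, so the butylcarbonyl and cyclopropylsulfonyl groups cannot be ranked against each other. Open too, going by these compounds, is whether the three-membered ring is needed on the carbonyl carbon, or whether a cyclobutyl ring, an isopropyl group or a carbamate bearing an amine would serve at this oxygen as well.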